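Cytotoxicity of three triazole analogues and a fourth

A few compounds are considered here, and "the series" means these few. Any claim that something is new, unique, unknown or untested is made for them only; others in the source may bear on it.

In a functional assay on PC-12 cells (Rattus norvegicus) for cytotoxicity, read by MTT assay, with stated times of 2 h and 24 h, tested at 1 uM (on this read-out lower numbers stand for a weaker effect and higher numbers for a stronger effect at the one concentration tested), compound 1 `CC(C)(C)c1ccc(-n2nc(-c3ccc(C(F)(F)F)cc3O)nc2-c2ccccc2O)cc1` gives 67.3%, compound 2 `Oc1cc(C(F)(F)F)ccc1-c1nc(-c2ccccc2O)n(-c2ccc(I)cc2)n1` gives 70.1% and compound 3 `N#Cc1ccc(-n2nc(-c3ccc(C(F)(F)F)cc3O)nc2-c2ccccc2O)cc1` gives 66.6%. Among the measured compounds shown here, compound 3 holds the lowest of the three numbers, but all three sit close together: the steps of a number 2.8 percentage points higher from compound 1 to compound 2 (within the scatter), a number 0.7 percentage points lower from compound 1 to compound 3 (within the scatter) and a number 3.5 percentage points lower from compound 2 to compound 3 (within the scatter) each stay within the scatter, so no compound can be called more or less active than another.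

Compound 4 `Oc1cc(C(F)(F)F)ccc1-c1nc(-c2ccccc2O)n(-c2ccccc2C(F)(F)F)n1` departs from compound 3 by 2-(trifluoromethyl)phenyl in place of 4-cyanophenyl on an aromatic nitrogen. The three measured steps all exchange the group on the aromatic carbon of that same phenyl ring, and none of them moved the read-out beyond the scatter. Those steps bear on the present change only indirectly, since the whole phenyl group is exchanged here rather than one substituent on it. On this basis the step of a number 0.4 percentage points higher from compound 3 to compound 4 (within the scatter) is expected to be small and without a clear direction. Compound 4 is therefore estimated at 67%, with a range from 55% to 78%.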

Compound 4, a percentage reported as activity, at one concentration (the size of the read-out at that concentration, not a potency): 71%
Compound 4: the middle estimate sits 4 percentage points below what was measured; measured number inside the range.
By their numbers in this assay, from the lowest: compounds 3, 1, 2 and 4 (each within the scatter of the next).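

Compound 4 is the only one of the four with 2-(trifluoromethyl)phenyl on the aromatic nitrogen, while the others carry 4-(tert-butyl)phenyl, 4-iodophenyl or 4-cyanophenyl there. Even so, in this assay the steps of a number 4.4 percentage points higher from compound 3 to compound 4 (within the scatter) and a number 0.9 percentage points higher from compound 2 to compound 4 (within the scatter) and a number 3.7 percentage points higher from compound 1 to compound 4 (within the scatter) show that exchanging the whole phenyl group for this one leaves the four numbers indistinguishable, which extends the flat picture from changes among those three groups to this different group. Nothing at hand explains why the read-out stays level at this position.

As far as these compounds go, whether an amine, a carboxylic acid or a longer alkyl chain on this phenyl ring would also leave the number unchanged remains open. So does whether a group without a phenyl ring would do so on the aromatic nitrogen.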